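N-Methylation of the Compound 1 Core: Expected Effect

The compounds below may be only part of what the source reports. "The series", "measured", "known", "first", "only" and "open" are said of these compounds alone.

For the measured compounds named here, compound 1 `C[C@@H]1CCCN1c1[nH]c2ncnc(N)c2c1C#N` is the weakest of the three measured members in an assay on isolated protein for inhibition of Leucine-rich repeat serine/threonine-protein kinase 2 (Homo sapiens), read by TR-FRET and LanthaScreen, with stated times of 50 min and 30 min, in the presence of a further agent that is not named here (on this read-out lower numbers stand for stronger inhibition and higher numbers for weaker inhibition), giving 166 nM. Compound 2 `C[C@@H]1CCCN1c1c(C#N)c2c(N)nccc2n1C` gives 34 nM in this assay, and compound 3 `Cc1c(Nc2nc(N)c3c(C#N)c(N4CCC[C@H]4C)n(C)c3n2)cnn1CC1(O)COC1` gives 16 nM; both lie beyond the scatter below compound 1, and both carry a methyl on an aromatic nitrogen where compound 1 carries a hydrogen. Going by the values given here, no direct one-change pair among the measured compounds isolates that substitution, so its size has to be inferred.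

Compound 4 `C[C@@H]1CCCN1c1c(C#N)c2c(N)ncnc2n1C` applies exactly this change to the core of compound 1: methyl in place of hydrogen on an aromatic nitrogen. Given that compound 2, which shares the methyl on the aromatic nitrogen, gives 34 nM, the step is expected to be a clear fall in number, beyond the scatter, at roughly a 4.2-fold lower number from compound 1 to compound 4 (0.62 log units; beyond the scatter). Compound 4 is therefore estimated to give 40 nM in this assay, with a likely range from 15 nM to 120 nM; a figure close to compound 2 would not be surprising.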

Compound 4, half-maximal inhibitory concentration: 15 nM
Beside the measured number, compound 4's estimate is 2.7-fold (0.43 log units) above it, within the range that was stated.
By their numbers in this assay, from the lowest: compounds 4 and 3 (each within the scatter of the next); then compound 2; then compound 1.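

In this assay, for the compounds shown here, methyl in place of hydrogen on the aromatic nitrogen gives an 11-fold lower number from compound 1 to compound 4 (1.04 log units; beyond the scatter), the first one-change reading of this substitution, and the step is large. The position, next to the ring atom that bears the 2-methylpyrrolidin-1-yl group and two ring bonds from the ring atom that bears the cyano group, therefore accepts a methyl, and that single carbon alone moves the number beyond the scatter. No measured property is available to account for the size of this step.

As far as these compounds go, whether an ethyl group, a longer chain or a chain ending in an amine on this nitrogen would keep the step stays open. From the compounds shown here alone, whether the same step carries over to the cores of compound 2 and compound 3 also stays open.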